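The source may report more compounds than this note shows. Statements on the series, on what has been measured and on what is new or still open speak of the compounds shown alone.

Of the compounds shown here, three built on one shared core have been tested in an assay on CHO cells for antagonist activity at transient receptor potential cation channel subfamily V member 1 (Homo sapiens), read by FLIPR; a higher number here means a weaker inhibitor, a lower number a stronger inhibitor. Compound 1 `CC(C(=O)NCc1ccc(C(F)(F)F)cc1SC1CCCC1)c1ccc(NS(C)(=O)=O)c(F)c1` gives 0.3 nM. Compound 2 `CCCCCc1cc(C(F)(F)F)ccc1CNC(=O)C(C)c1ccc(NS(C)(=O)=O)c(F)c1` gives 0.4 nM. Compound 3 `CC(C(=O)NCc1ccc(C(F)(F)F)cc1-c1ccc(C(C)(C)C)cc1)c1ccc(NS(C)(=O)=O)c(F)c1` gives 1.1 nM, the highest of the three numbers. The steps of a 3.7-fold higher number from compound 1 to compound 3 (0.56 log units; beyond the scatter) and a 2.8-fold higher number from compound 2 to compound 3 (0.44 log units; beyond the scatter) both lie beyond the usual scatter, while a 1.3-fold higher number from compound 1 to compound 2 (0.12 log units; within the scatter) lies within it.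

Compound 4 `CC(C(=O)NCc1ccc(C(F)(F)F)cc1-c1cccc(F)c1)c1ccc(NS(C)(=O)=O)c(F)c1` differs from compound 3 in one place: 3-fluorophenyl in place of 4-(tert-butyl)phenyl on an aromatic carbon. Within the data shown here, none of the measured pairs swaps one aromatic group for another on this carbon, so no step speaks directly to this change. The two steps that end at compound 3 only show that the 4-(tert-butyl)phenyl group gave modestly higher numbers than either the cyclopentylsulfanyl or the pentyl group. Exchanging it for a different aromatic group could move the number either way, and nothing here settles the direction. Compound 4 is therefore expected to stay near the figure of compound 3. The step of a 1.4-fold higher number from compound 3 to compound 4 (0.13 log units; within the scatter) is expected to be small. The estimate for compound 4 in this assay is 1.5 nM, with a range from 0.5 nM to 5 nM.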

Compound 4, inhibition constant: 1.9 nM
Estimate against measurement, compound 4: 1.3-fold (0.10 log units) below; the range from low to high includes it.
By their numbers in this assay, from the lowest: compounds 1 and 2 (each within the scatter of the next); then compounds 3 and 4 (each within the scatter of the next).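

In this assay, replacing 4-(tert-butyl)phenyl with 3-fluorophenyl gives a 1.7-fold higher number from compound 3 to compound 4 (0.24 log units; within the scatter), so this position tolerates this change of substituents on the phenyl ring without a measurable shift. The new compound also strengthens the earlier contrast at this carbon, with a 4.8-fold higher number from compound 2 to compound 4 (0.68 log units; beyond the scatter) and a 6.3-fold higher number from compound 1 to compound 4 (0.80 log units; beyond the scatter), so both phenyl-bearing compounds, compound 3 and compound 4, give higher numbers than the pentyl and cyclopentylsulfanyl compounds, and none of the four goes against this. No available evidence explains this difference.

From the compounds shown here alone, what remains open is how a plain phenyl, or a phenyl ring carrying an amine or a carboxylic acid, would behave at this carbon. A chain longer than pentyl, or a cyclohexylsulfanyl group, could also show how far the lower numbers extend.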